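Fluoro in place of methoxy: working notes on the series

A few compounds are considered here, and "the series" means these few. Any claim that something is new, unique, unknown or untested is made for them only; others in the source may bear on it.

Measured in a functional assay on A549 cells (Homo sapiens) for antiproliferative activity, read by MTT assay, with a stated time of 72 h; a higher number here means a weaker inhibitor, a lower number a stronger inhibitor:
- compound 1 `Cc1ccc(-c2noc(CCCCCCC(=O)NO)n2)cc1`: 5810 nM
- compound 2 `COc1ccc(-c2noc(CCCCCCC(=O)NO)n2)cc1`: 13500 nM

Of the two measured compounds, compound 2 has the higher number at 13500 nM, which makes it the weaker inhibitor of the pair in this assay. Compound 3 `O=C(CCCCCCc1nc(-c2ccc(F)cc2)no1)NO` carries fluoro in place of methoxy on an aromatic carbon, para to a large group: fluoro in place of methoxy on an aromatic carbon. Among the measured compounds shown here, the only measured step that bears on this change is a 2.3-fold higher number from compound 1 to compound 2 (0.37 log units; beyond the scatter), a modest step beyond the scatter for methoxy in place of methyl. For the measured compounds named here, no fluoro compound has been measured, so this step is only a rough guide. Losing the methoxy is expected to give a modest step to a lower number, similar in size to that one. The expected change is a 2.1-fold lower number from compound 2 to compound 3 (0.32 log units; beyond the scatter). For compound 3 the estimate is 6500 nM, with an expected range of 2500 nM to 15000 nM.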

Compound 3, half-maximal inhibitory concentration: 5770 nM
The estimate for compound 3 lay 1.1-fold (0.05 log units) above the measured number; the measured number falls inside the stated range.
By their numbers in this assay, from the lowest: compounds 3 and 1 (each within the scatter of the next); then compound 2.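

Fluoro in place of methoxy gives a 2.3-fold lower number from compound 2 to compound 3 (0.37 log units; beyond the scatter) in this assay on the aromatic carbon para to a large group. That step matches in size the earlier step between compound 1 and compound 2, now from a second group. Fluoro in place of methyl gives a 1.0-fold lower number from compound 1 to compound 3 (0.00 log units; within the scatter) and thus places the two groups together in this assay, with methoxy alone apart among the three compounds. Nothing at hand accounts for why methoxy stands apart.

On these data alone, whether chloro, trifluoromethyl or nitrile at the same place would sit with fluoro and methyl or with methoxy remains open. Also open, as far as these compounds go, is whether the same order of groups would hold with a longer chain on the shared core.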